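The source may hold more compounds than are shown below. What is called first, only, known or untested is meant among the compounds shown, and "the series" means these compounds.

Two compounds share one core and differ only in the aryl group on an amine nitrogen. Compound 1 `COc1ccc(N/C(CCNC2=CC(=O)c3ccccc3C2=O)=N\S(=O)(=O)c2ccc(C)cc2)cc1` carries a 4-methoxyphenyl there, and in an ADME assay on HEK293 cells (Homo sapiens) for cytotoxicity, read by MTT assay, with a stated time of 48 h (a lower number here means a stronger inhibitor, a higher number a weaker inhibitor), compound 1 gives 35100 nM. Compound 2 `Cc1ccc(S(=O)(=O)/N=C(/CCNC2=CC(=O)c3ccccc3C2=O)Nc2cccc(C)c2)cc1` carries a 3-methylphenyl instead, and in this assay compound 2 gives 56200 nM. The step of a 1.6-fold higher number from compound 1 to compound 2 (0.20 log units; within the scatter) places compound 2 alongside compound 1, the two numbers lying within the scatter of each other.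

Compound 3 `Cc1ccc(S(=O)(=O)/N=C(/CCNC2=CC(=O)c3ccccc3C2=O)Nc2ccc(F)c(F)c2)cc1` is the next member: 3,4-difluorophenyl in place of 3-methylphenyl on an amine nitrogen. Among the measured compounds shown here, only one measured step bears on this change, the aryl swap from compound 1 to compound 2, and it stayed within the scatter. With the swap again confined to this aryl group, no step beyond the scatter is expected in this assay, so the expected step from compound 2 to compound 3 is a 1.1-fold lower number from compound 2 to compound 3 (0.05 log units; within the scatter). Compound 3 is therefore estimated at 50000 nM, with a range from 20000 nM to 125000 nM.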

Compound 3, half-maximal inhibitory concentration: 55200 nM
The estimate for compound 3 lay 1.1-fold (0.04 log units) below the measured number; low and high end bracket the measured number.
By their numbers in this assay, from the lowest: compounds 1, 3 and 2 (each within the scatter of the next).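

Putting 3,4-difluorophenyl in place of 3-methylphenyl on the amine nitrogen gives a 1.0-fold lower number from compound 2 to compound 3 (0.01 log units; within the scatter) and putting it in place of 4-methoxyphenyl gives a 1.6-fold higher number from compound 1 to compound 3 (0.20 log units; within the scatter). Both steps lie within the scatter, so in this assay this position now holds three differently substituted phenyl groups, one of them with two fluorine atoms, and their numbers cannot be told apart. No measurement at hand offers an explanation for this result.

As far as these compounds go, all three compounds keep a six-membered aromatic ring of carbon only on this nitrogen, so it remains open whether a cyclohexyl group or a plain methyl group there would read differently. From the compounds shown here alone, it also remains open whether a longer chain elsewhere on the shared core would move the number beyond the scatter.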